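Lengthening the acid chain on a selenocyanate anilide

The compounds below may be only part of what the source reports. "The series", "measured", "known", "first", "only" and "open" are said of these compounds alone.

Compound 1, `N#C[Se]c1ccc(NC(=O)CCC(=O)O)cc1`, carries a selenocyanate group on a benzene ring and, on the other side, an amide that ends in a short chain with a carboxy group. In a functional assay on HepG2 cells (Homo sapiens) for cytotoxicity, read by MTT assay, with a stated time of 48 h (on this read-out higher numbers stand for weaker inhibition and lower numbers for stronger inhibition), compound 1 is reported as "not active" (no number reported), so no single number can be placed for it; it stands without a measured value. Two related compounds give numbers on the same read-out. Compound 2, `N#C[Se]c1ccc(N2C(=O)CCCC2=O)cc1`, in which the acid chain is closed into a ring on the nitrogen, gives 47000 nM in this assay. Compound 3, `O=C(O)/C=C\C(=O)Nc1ccc([Se][Se]c2ccc(NC(=O)/C=C\C(=O)O)cc2)cc1`, a dimer joined through two selenium atoms with an unsaturated acid on each amide, gives 3000 nM in this assay.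

Compound 4, `N#C[Se]c1ccc(NC(=O)CCCC(=O)O)cc1`, differs from compound 1 in one place: carboxymethyl in place of carboxy on a saturated chain carbon, two bonds along the chain from a carbonyl carbon. This adds one chain carbon between the amide and the acid. Nothing among the measured compounds isolates this change, and compound 1 itself has no number, so the size of the step cannot be read from the data; on what is shown, weak activity or none beyond the scatter is the expectation. Compound 4 is estimated to give about 60000 nM in this assay, with a range from 20000 nM to 200000 nM.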

Compound 4, half-maximal inhibitory concentration: 7000 nM
The estimate for compound 4 lay 8.6-fold (0.93 log units) above the measured number, outside the stated range (below it).
By their numbers in this assay, from the lowest: compound 3; then compound 4; then compound 2.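

Going by these compounds alone, compound 4 gives 7000 nM in this assay while compound 1 has no single number, so no step between compound 1 and compound 4 can be read. Nothing shown offers an explanation for this result. The compounds shown leave open how much the longer acid chain itself contributes to the activity of compound 4.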